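The source may report more compounds than this note shows. Statements on the series, on what has been measured and on what is new or still open speak of the compounds shown alone.

Of the compounds shown here, three built on one shared core have been measured in a functional assay on aorta for antagonist activity at Alpha-1D adrenergic receptor (Rattus norvegicus); on this read-out lower numbers stand for tighter binding and higher numbers for weaker binding. Compound 1 `CN(C)C(=O)c1cccnc1NCCCN1CCN(c2ccccc2O)CC1` gives 63.1 nM. Compound 2 `CN(C)C(=O)c1cccnc1NCCCN1CCN(c2ccccc2OCC(F)(F)F)CC1` gives 15.9 nM. Compound 3 `Cc1ccccc1N1CCN(CCCNc2ncccc2C(=O)N(C)C)CC1` gives 10 nM; it stands clearly apart from compound 1, by a 6.3-fold lower number from compound 1 to compound 3 (0.80 log units; beyond the scatter), and essentially level with compound 2, since a 1.6-fold lower number from compound 2 to compound 3 (0.20 log units; within the scatter) falls inside the usual scatter.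

Compound 4 `CN(C)C(=O)c1cccnc1NCCCN1CCN(c2ccccc2C2CC2)CC1` has not yet been measured. It differs from compound 3 in a single place: cyclopropyl in place of methyl on an aromatic carbon. The change sits on an aromatic carbon of a six-membered aromatic ring of carbon only, ortho to a large group.

Within the data shown here, two measured steps touch this same spot. Exchanging hydroxy for methyl gave a 6.3-fold lower number from compound 1 to compound 3 (0.80 log units; beyond the scatter), and exchanging 2,2,2-trifluoroethoxy for methyl gave a 1.6-fold lower number from compound 2 to compound 3 (0.20 log units; within the scatter). Among the measured compounds shown here, both steps end at compound 3, so what they show is that a carbon group here reads at least as well as the oxygen-bearing groups tried; no step from a small carbon group to a larger one has been measured. On that basis compound 4 is expected to stay close to compound 3 in this assay, with a step of a 1.3-fold lower number from compound 3 to compound 4 (0.10 log units; within the scatter) and no clear direction beyond the scatter. Compound 4 is estimated at 8 nM, within a range from 3 nM to 25 nM.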

Compound 4, dissociation constant: 63.1 nM
Compound 4: the middle estimate sits 7.9-fold (0.90 log units) below what was measured; measured number outside the range, above it.
By their numbers in this assay, from the lowest: compounds 3 and 2 (each within the scatter of the next); then compounds 1 and 4 (each within the scatter of the next).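

In this assay this position does not treat all carbon groups alike: cyclopropyl in place of methyl, which takes the group from 1 heavy atom to 3 and adds a three-membered ring, gave a 6.3-fold higher number from compound 3 to compound 4 (0.80 log units; beyond the scatter) and so lost ground. The earlier steps shown here all ended at methyl, so they could not separate carbon groups in general from methyl in particular; the new result shows that the advantage seen for methyl does not extend to cyclopropyl, which also reads worse than 2,2,2-trifluoroethoxy, with a 4.0-fold higher number from compound 2 to compound 4 (0.60 log units; beyond the scatter) and stands level with hydroxy, with no change at the digits printed from compound 1 to compound 4 (within the scatter) as the step. No measured property of these groups is available to account for the loss, so the data give the size of the step and not its cause.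

The compounds shown leave open whether the step depends on the ring itself or simply on the added carbons, a question that an ethyl or isopropyl group at this spot would help to settle. Also open, from the compounds shown here alone, is how a chlorine or methoxy group here would read against methyl.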